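The source may report more compounds than this note shows. Statements on the series, on what has been measured and on what is new or still open speak of the compounds shown alone.

In a functional assay on the whole organism with Rattus norvegicus as the target (a lower number here means that less compound is needed, a higher number that more compound is needed for the effect), compound 1 `CCOCCOC(=O)C(=O)Nc1nc(-c2cc(Br)no2)cs1` gives 11 mg/kg, compound 2 `CCOCCOC(=O)C(=O)Nc1nc(-c2cc(OC)no2)cs1` gives 3 mg/kg, and compound 3 `CCOCCOC(=O)C(=O)Nc1nc(-c2cc(C)on2)cs1` gives 1.3 mg/kg, the lowest number of the three. Compound 4 `CCOCCOC(=O)C(=O)Nc1nc(-c2cc(CO)on2)cs1` differs from compound 3 in one place: hydroxy in place of hydrogen on a saturated chain carbon bound to an aromatic carbon. Hydroxy replaces hydrogen on a saturated chain carbon bound to an aromatic carbon, turning methyl into hydroxymethyl. Among the measured compounds shown here, no measured step makes this same change. The closest guides are a 3.7-fold lower number from compound 1 to compound 2 (0.56 log units; beyond the scatter), a swap of bromo for methoxy, and two exchanges of the whole ring group, a 2.3-fold lower number from compound 2 to compound 3 (0.36 log units; beyond the scatter) and an 8.5-fold lower number from compound 1 to compound 3 (0.93 log units; beyond the scatter). All three are modest, though beyond the scatter, even where a whole group was exchanged. A smaller change is therefore expected here, and the direction is uncertain. The expected result is a 1.5-fold higher number from compound 3 to compound 4 (0.19 log units; within the scatter), slightly upward and within the scatter. For compound 4 the estimate is 2 mg/kg, with an expected range of 0.6 mg/kg to 7 mg/kg.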

Compound 4, dose for half-maximal effect: 1.8 mg/kg
Beside the measured number, compound 4's estimate is 1.1-fold (0.05 log units) above it; the measured number falls inside the stated range.
By their numbers in this assay, from the lowest: compounds 3, 4 and 2 (each within the scatter of the next, the first and the last beyond it); then compound 1.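

In this assay turning methyl into hydroxymethyl gives a 1.4-fold higher number from compound 3 to compound 4 (0.14 log units; within the scatter) and so adds a hydroxy on this saturated chain carbon without a shift beyond the scatter. The hydroxymethyl compound also stays within the scatter of the methoxy compound, with a 1.7-fold lower number from compound 2 to compound 4 (0.22 log units; within the scatter) as the step, while a 6.1-fold lower number from compound 1 to compound 4 (0.79 log units; beyond the scatter) keeps it clearly apart from the bromo compound. Nothing measured here explains these numbers. From the compounds shown here alone, whether an amine, a carboxylic acid or a longer chain bearing hydroxy would be accepted at this carbon stays open.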